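A few compounds are considered here, and "the series" means these few. Any claim that something is new, unique, unknown or untested is made for them only; others in the source may bear on it.

Measured compounds:
compound 1 `CNC(=O)c1cc(Oc2ccc(NC(=O)c3nn(-c4ccccc4C(F)(F)F)c(=O)cc3C)cc2F)ccn1`, 35700 nM
compound 2 `O=C(Nc1ccc(Oc2ncnc3ccsc23)c(F)c1)c1nn(-c2ccc(F)cc2)ccc1=O`, 5720 nM
compound 3 `O=C(Nc1ccc(Oc2ncnc3ccsc23)c(F)c1)c1nn(-c2ccc(Br)cc2)ccc1=O`, 9620 nM

These three numbers come from a functional assay on MCF7 cells (Homo sapiens) for cytotoxicity, read by MTT assay, with a stated time of 72 h; on this read-out lower numbers stand for stronger inhibition and higher numbers for weaker inhibition. Compound 3 stands second highest of the three: compound 2 lies close to it, and the gap between them, a 1.7-fold higher number from compound 2 to compound 3 (0.23 log units; within the scatter), is within the scatter, while compound 1 sits further off, beyond the scatter.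

The next step is from compound 3 to compound 4 `Cc1ccc(-n2ccc(=O)c(C(=O)Nc3ccc(Oc4ncnc5ccsc45)c(F)c3)n2)cc1`, not yet measured in this assay. The change is methyl in place of bromo on an aromatic carbon; cut one bond further out it reads 4-bromophenyl to 4-methylphenyl, on an aromatic carbon of a six-membered aromatic ring of carbon only, para to a large group.

Within the data shown here, only one measured step touches this position, from compound 2 to compound 3, and it stayed within the scatter. Among the measured compounds shown here, no measured step replaces a halogen by methyl here, so nothing points to a move beyond the scatter in either direction. The expected step, a 1.2-fold lower number from compound 3 to compound 4 (0.08 log units; within the scatter), is therefore close to none. Compound 4 is estimated at 8000 nM, within 3000 nM to 25000 nM.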

Compound 4, half-maximal inhibitory concentration: 23200 nM
Compound 4: middle estimate off by 2.9-fold (0.46 log units), on the low side; the range from low to high includes it.
By their numbers in this assay, from the lowest: compounds 2 and 3 (each within the scatter of the next); then compounds 4 and 1 (each within the scatter of the next).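

In this assay the 4-substituted phenyl position proves sensitive to this change: going from 4-bromophenyl to 4-methylphenyl gives a 2.4-fold higher number from compound 3 to compound 4 (0.38 log units; beyond the scatter), a step toward weaker inhibition that lies beyond the scatter, and the comparison with fluoro gives a 4.1-fold higher number from compound 2 to compound 4 (0.61 log units; beyond the scatter), also beyond the scatter. The earlier halogen exchange, a 1.7-fold higher number from compound 2 to compound 3 (0.23 log units; within the scatter), stayed within the scatter, so the two halogens are not separated here while methyl stands apart from both, the first replacement at this position to do so. No measurement in hand accounts for this difference.

Going by these compounds, whether the shift is particular to methyl or extends to other non-halogen groups remains open, since an amine, a methoxy group, a carboxylic acid or a longer chain such as ethyl does not appear at this position. On these data alone, whether the same change would have a similar effect on the core of compound 1 also remains open.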